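Trimming the amine chain of compound 3

This account rests on a few compounds, and the source may have more. Where it says the series, first, only, none or still open, it means among the compounds named here.

Compound 1 `CCCNc1nc(C)nc2c1cnn2-c1ccccc1` gives in a functional assay on G-361 cells (Homo sapiens) for cytotoxicity, read by sulforhodamine B assay (on this read-out higher numbers stand for weaker inhibition of growth and lower numbers for stronger inhibition of growth), the value > 100000 nM, which is a limit of the assay and not a number.
Compound 2 `Cc1nc(NC(C)C)c2cnn(-c3ccccc3)c2n1` gives in this assay the value > 100000 nM, again a limit of the assay.
Compound 3 `Cc1nc(NCc2ccccc2)c2cnn(-c3ccccc3)c2n1` gives in this assay the value > 100000 nM, also a limit of the assay.

Among the compounds with values here, compound 3 therefore stands where every compound measured so far stands: at the limit of the assay, with no number of its own, as the limit of > 100000 nM in this assay, at which 3 of the 3 values shown sit, shows. The three compounds share one core and differ only in the group on the ring nitrogen, yet none of the steps between them can be read: a step that the two limits leave unreadable from compound 1 to compound 2, a step that the two limits leave unreadable from compound 1 to compound 3 and a step that the two limits leave unreadable from compound 2 to compound 3 are all hidden behind the two limits.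

Compound 4 `CCNc1nc(C)nc2c1cnn2-c1ccccc1` is the next variation. Its difference from compound 3 is methyl in place of phenyl on a saturated chain carbon bound to a nitrogen on an aromatic ring: the chain on the ring nitrogen is shortened from benzylamino to ethylamino. Within the data shown here, no measured step gives a size or a direction for such a change here, since every step among compounds 1, 2 and 3 is unreadable. Without a readable step, the expectation for compound 4 rests on its nearness to three compounds at the limit: compound 4 is expected to give about 100000 nM in this assay, most likely again as a limit, within a range of 50000 nM to 300000 nM. This estimate means a step of a number no higher from compound 3 to compound 4 (the limit leaves the size open), that is, no step beyond the scatter.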

Compound 4, concentration for total growth inhibition: > 100000 nM
Compound 4 gave a limit, no number (the forecaster's own chance of this, stated with the estimate: 85%); the middle value sits exactly at the limit.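

In this assay, within the data shown here, compound 4 gives > 100000 nM, a limit and not a number, so no step from compound 1, compound 2 or compound 3 to compound 4 can be read. The compounds shown leave open whether changing the amine chain on the shared core alters growth inhibition at all, as each sits at the same limit: the limit of > 100000 nM in this assay, at which 4 of the 4 values shown sit.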